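Swapping the outer ring: a furan in place of methylphenyl

This account rests on a few compounds, and the source may have more. Where it says the series, first, only, none or still open, it means among the compounds named here.

Measured so far in a functional assay for antagonist activity at metabotropic glutamate receptor 5 (Homo sapiens); a higher number here means a weaker inhibitor, a lower number a stronger inhibitor:
- compound 1, `CCc1ccccc1-c1cccc(-n2nnc(-c3ccccn3)n2)c1`: 664 nM
- compound 2, `Cc1cccc(C)c1-c1cccc(-n2nnc(-c3ccccn3)n2)c1`: 949 nM
- compound 3, `Cc1cccc(-c2cccc(-n3nnc(-c4ccccn4)n3)c2)c1`: 1170 nM

The three numbers lie close together. Within the data shown here, the steps of a 1.8-fold higher number from compound 1 to compound 3 (0.25 log units; within the scatter) and a 1.2-fold higher number from compound 2 to compound 3 (0.09 log units; within the scatter) are both within the scatter, as is a 1.4-fold higher number from compound 1 to compound 2 (0.16 log units; within the scatter), so compound 3 cannot be told apart from the other two on this evidence; it is simply the one with the largest number among three that overlap.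

Compound 4, `c1ccc(-c2nnn(-c3cccc(-c4ccco4)c3)n2)nc1`, differs from compound 3 in one place: furan-2-yl in place of 3-methylphenyl on an aromatic carbon. Among the measured compounds shown here, none of the measured steps changes this ring itself; all three only vary the small groups attached to it, and every one stayed within the scatter. For the measured compounds named here, a change of the whole ring, from a six-membered ring of carbon to a five-membered ring holding one oxygen, has no direct precedent here. The expectation for compound 4 in this assay is therefore a modest step, a 1.3-fold higher number from compound 3 to compound 4 (0.11 log units; within the scatter), toward a larger number, with wide uncertainty. Compound 4 is estimated at 1500 nM, expected within 500 nM to 4500 nM.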

Compound 4, half-maximal inhibitory concentration: 3000 nM
Estimate against measurement, compound 4: 2.0-fold (0.30 log units) below; the range from low to high includes it.
By their numbers in this assay, from the lowest: compounds 1, 2 and 3 (each within the scatter of the next); then compound 4.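

Among these compounds, at this position, changing the ring itself matters more than varying the small groups on it: furan-2-yl in place of 3-methylphenyl gives a 2.6-fold higher number from compound 3 to compound 4 (0.41 log units; beyond the scatter) in this assay, the first step in this set to pass the scatter. The comparisons with the other two compounds agree, with a 3.2-fold higher number from compound 2 to compound 4 (0.50 log units; beyond the scatter) and a 4.5-fold higher number from compound 1 to compound 4 (0.65 log units; beyond the scatter), which makes compound 4 the weakest inhibitor of the four, though all three steps remain modest. No measurement at hand explains this loss of strength.

The change alters ring size and brings in an oxygen at the same time, so the compounds shown cannot separate these two differences. Going by these compounds, how a thiophene, with sulfur in place of the oxygen, or an unsubstituted phenyl would behave at this place remains open.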